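The compounds below may be only part of what the source reports. "The series", "measured", "known", "first", "only" and "open" are said of these compounds alone.

Going by the values given here, in an ADME assay on the whole organism (strain Sprague-Dawley) for pharmacokinetics, with Rattus norvegicus as the target, at a dose of 5 mg/kg by the oral route (on this read-out lower numbers stand for lower exposure and higher numbers for higher exposure at the dose given), compound 2 (`COc1c(/C=C/c2ccc(NS(C)(=O)=O)cc2)cc(N2CCC(=O)NC2=O)cc1C(C)(C)C`) gives 1520 ng.h/mL, the lower of the two numbers so far. Compound 1 (`COc1c(/C=C/c2ccc(NS(C)(=O)=O)c(F)c2)cc(-n2ccc(=O)[nH]c2=O)cc1C(C)(C)C`) gives 10400 ng.h/mL, a higher number beyond the usual scatter. Compound 3 (`COc1c(/C=C/c2ccc(NS(C)(=O)=O)cc2)cc(-n2ccc(=O)[nH]c2=O)cc1C(C)(C)C`) has not yet been measured. Its structure departs from that of compound 2 in one place: a group of 8 heavy atoms (4 carbon, 2 nitrogen, 2 oxygen; one six-membered aromatic ring with 2 hetero atoms) in place of a group of 8 heavy atoms (4 carbon, 2 nitrogen, 2 oxygen; one six-membered non-aromatic ring with 2 hetero atoms), on an aromatic carbon. A group with a six-membered aromatic ring with 2 hetero atoms replaces one with a six-membered non-aromatic ring with 2 hetero atoms, on an aromatic carbon. Among the compounds with values here, no measured pair isolates this change, so its size in this assay rests on thin evidence. Compound 1, which also carries the aromatic ring group, stands at 10400 ng.h/mL, so a rise covering part of that gap is expected. The expected step of a 3.0-fold higher number from compound 2 to compound 3 (0.47 log units; beyond the scatter) is upward and beyond the scatter. For compound 3 the estimated value is 4500 ng.h/mL, with an expected range from 1800 ng.h/mL to 11000 ng.h/mL.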

Compound 3, area under the concentration-time curve: 2520 ng.h/mL
Compound 3: the middle estimate sits 1.8-fold (0.25 log units) above what was measured; low and high end bracket the measured number.
By their numbers in this assay, from the lowest: compounds 2 and 3 (each within the scatter of the next); then compound 1.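

In this assay, the aromatic ring group in place of the non-aromatic ring group, on this aromatic carbon para to a methoxy group, gives a 1.7-fold higher number from compound 2 to compound 3 (0.22 log units; within the scatter), so this pair shows no clear effect of the ring change on exposure. The step that stands out is at another place: hydrogen in place of fluoro gives a 4.1-fold lower number from compound 1 to compound 3 (0.62 log units; beyond the scatter), so the high number of compound 1 goes with its fluoro group and not with the aromatic ring group alone. Nothing measured here gives a cause for either step.

From the compounds shown here alone, whether the fluoro step would hold with the non-aromatic ring group in place stays open. Also open, going by these compounds, is how an amine or an open-chain urea at the ring position, or a chloro or methyl group in place of the fluoro, would read.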